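This account rests on a few compounds, and the source may have more. Where it says the series, first, only, none or still open, it means among the compounds named here.

Compound 2 `Oc1cccc(-c2nc(N3CCCCC3)c3nc[nH]c3n2)c1` stands at the limit of > 80% in this assay, at which 2 of the 3 values shown sit. In an assay on cells for displacement of a labelled ligand from adenosine receptor A1 (Homo sapiens), read by scintillation counting and radioligand binding, with a stated time of 60 min, tested at 10 uM (a higher number here means more inhibition at the concentration tested (going by the name of the read-out), a lower number less inhibition), compound 2 gives > 80%, which is a limit of the assay rather than a number. Compound 4 `Cn1cnc2c(N3CCCCC3)nc(-c3cccc(O)c3)nc21` differs from it by methyl in place of hydrogen on an aromatic nitrogen. One measured step of this kind exists, running the other way. Compound 1 `CN1CCN(c2nc(-c3cccc(Cl)c3)nc3c2ncn3C)CC1` gives 45.7% in this assay. Compound 3 `CN1CCN(c2nc(-c3cccc(Cl)c3)nc3[nH]cnc23)CC1` gives > 80%, again a limit. That step, a number at least 34.3 percentage points higher from compound 1 to compound 3 (beyond the scatter), is large and beyond the scatter, so the methyl entering in compound 4 is expected to lower inhibition by a large step, a number at least 35 percentage points lower from compound 2 to compound 4 (beyond the scatter). Compound 4 is therefore estimated at 45%, with a range from 25% to 70%.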

Compound 4, a percentage reported as inhibition, at one concentration (the size of the read-out at that concentration, not a potency): 78.5%
Compound 4: middle estimate off by 33.5 percentage points, on the low side; the whole stated range lies below it.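

In this assay the change reads as a number at least 1.5 percentage points lower from compound 2 to compound 4 (that floor lies within the scatter), so a large loss from methyl on this aromatic nitrogen is not established on the core of compound 2. The large step seen with compound 1 and compound 3 therefore does not simply carry over, yet the two steps cannot be ranked: the same change on two cores in this assay, a number at least 34.3 percentage points higher (beyond the scatter) from compound 1 to compound 3 and a number at least 1.5 percentage points higher (that floor lies within the scatter) from compound 4 to compound 2; the limit leaves it open whether they differ

On these data alone, for compound 2, > 80% is a limit, so the true size of its step stays open. As far as these compounds go, whether an ethyl group or a longer chain on this nitrogen would behave like methyl also stays open.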